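The compounds below may be only part of what the source reports. "The series", "measured", "known", "first", "only" and "open" are said of these compounds alone.

Compound 1 `CC(C)C(=O)NCCCc1cccc2c1C[C@@H](CCCCc1ccccc1)O2` sits at the high end of the three numbers gathered so far: in an assay on NIH3T3 cells for binding affinity to melatonin receptor type 1A (Homo sapiens) (a higher number here means a weaker inhibitor, a lower number a stronger inhibitor), compound 1 gives 4 nM. Its nearest neighbour on the numbers is compound 3 `CCCC(=O)NCCCc1cccc2c1C[C@@H](CCCCc1ccccc1)O2`, which in this assay gives 2 nM; the furthest is compound 2 `CCC(=O)NC[C@@H]1C[C@H]1c1cccc2c1C[C@@H](CCCCc1ccccc1)O2`, which in this assay gives 1 nM. The three steps read a 2.0-fold lower number from compound 1 to compound 3 (0.30 log units; within the scatter), a 4.0-fold lower number from compound 1 to compound 2 (0.60 log units; beyond the scatter) and a 2.0-fold higher number from compound 2 to compound 3 (0.30 log units; within the scatter).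

Compound 4 `CCNC(=O)NCCCc1cccc2c1C[C@@H](CCCCc1ccccc1)O2` is drawn from compound 1 by a single change: ethylamino in place of isopropyl on a carbonyl carbon. For the measured compounds named here, no measured step matches this change. Going by the values given here, the only step at the same place is the exchange of alkyl groups on the carbonyl carbon, a 2.0-fold lower number from compound 1 to compound 3 (0.30 log units; within the scatter), which stayed within the scatter. The other step, a 4.0-fold lower number from compound 1 to compound 2 (0.60 log units; beyond the scatter), reworks the chain attached to the aromatic carbon and does not speak to a change on the carbonyl carbon. Among the compounds with values here, nothing in the set tests an ethylamino group, or any hydrogen-bond donor, at this position, so the expectation rests on the small effect of the one carbonyl-carbon step. For compound 4 no step beyond the scatter is expected in this assay, no change at the digits printed from compound 1 to compound 4 (within the scatter). Compound 4 is accordingly estimated at 4 nM, with a range from 1.5 nM to 12 nM.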

Compound 4, inhibition constant: 9 nM
Compound 4: middle estimate off by 2.3-fold (0.35 log units), on the low side; measured number inside the range.
By their numbers in this assay, from the lowest: compounds 2, 3 and 1 (each within the scatter of the next, the first and the last beyond it); then compound 4.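

In this assay, ethylamino on the carbonyl carbon, which adds one hydrogen-bond donor, gives a step beyond the scatter against both alkyl groups at this place: a 2.3-fold higher number from compound 1 to compound 4 (0.35 log units; beyond the scatter), and a 4.5-fold higher number from compound 3 to compound 4 (0.65 log units; beyond the scatter). The earlier exchange of isopropyl for propyl stayed within the scatter, a 2.0-fold lower number from compound 1 to compound 3 (0.30 log units; within the scatter), so this place tolerated that alkyl swap but is not indifferent to every group on the carbonyl carbon, and compound 4 stands above both alkyl compounds. The step of a 9.0-fold higher number from compound 2 to compound 4 (0.95 log units; beyond the scatter) is the widest gap in the set, though it also carries the change of the 2-((propanoylamino)methyl)cyclopropyl chain, and no data at hand account for the rise.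

The compounds shown do not separate the contribution of the amino nitrogen from that of the ethyl group, which methylamino, propylamino or ethoxy on the same carbonyl carbon would help to resolve. On these data alone, it also remains open whether ethylamino would carry the same step on the 2-((propanoylamino)methyl)cyclopropyl chain of compound 2 in place of the propanoyl ethyl group.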